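The source may report more compounds than this note shows. Statements on the series, on what has been measured and on what is new or still open speak of the compounds shown alone.

Of the compounds shown here, three sharing one core have been measured. Compound 1 `Cc1ccccc1NC(=O)NC(CCN(C)C)c1ccc(Cl)cc1` gives 2290 nM in an assay on NIH3T3 cells with Urotensin-2 receptor (Homo sapiens) as the target; a higher number here means that more compound is needed for the effect, a lower number that less compound is needed. Compound 2 `COc1ccc(NC(=O)NC(CCN(C)C)c2ccc(Cl)cc2)cc1` gives 2000 nM in this assay, and compound 3 `CN(C)CCC(NC(=O)NCc1ccccc1)c1ccc(Cl)cc1` gives 2000 nM in this assay. Compound 3 sits level with compound 2, and together they hold the lowest of the three numbers; the remaining gap is a 1.1-fold lower number from compound 1 to compound 3 (0.06 log units; within the scatter). Compound 4 `COc1cccc(NC(=O)NC(CCN(C)C)c2ccc(Cl)cc2)c1` differs from compound 3 by 3-methoxyphenyl in place of benzyl on an amide-type nitrogen. Going by the values given here, two measured steps bear on this exchange, no change at the digits printed from compound 2 to compound 3 (within the scatter) and a 1.1-fold lower number from compound 1 to compound 3 (0.06 log units; within the scatter), both within the scatter. Among these three compounds, swapping the group on that nitrogen has moved nothing beyond the scatter, so the expected step is no change at the digits printed from compound 3 to compound 4 (within the scatter), with no change beyond the scatter. Compound 4 is therefore estimated at 2000 nM, within a range of 1000 nM to 4500 nM.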

Compound 4, half-maximal effective concentration: 1350 nM
For compound 4 the middle estimate is 1.5-fold (0.17 log units) above the measured one; the measured number falls inside the stated range.
By their numbers in this assay, from the lowest: compounds 4, 2, 3 and 1 (each within the scatter of the next).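

In this assay the 3-methoxyphenyl group on the amide-type nitrogen stays within the scatter of all three earlier groups, with a 1.5-fold lower number from compound 3 to compound 4 (0.17 log units; within the scatter) and a 1.5-fold lower number from compound 2 to compound 4 (0.17 log units; within the scatter) and also a 1.7-fold lower number from compound 1 to compound 4 (0.23 log units; within the scatter). The step from 4-methoxyphenyl thus shows no change beyond the scatter between these two methoxy-bearing groups, and the step from benzyl shows none with the hydrogen-bond acceptor that 3-methoxyphenyl adds. No evidence accompanies these values to account for them. The compounds shown leave open whether a carboxylic acid or an amine on that aromatic ring, or a longer chain on that nitrogen, would give a step beyond the scatter.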